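The source may report more compounds than this note shows. Statements on the series, on what has been measured and on what is new or still open speak of the compounds shown alone.

Measured so far:
compound 1, `CC(C)c1cccc(C(C)C)c1NC(=O)N(C)C(=O)N(c1ccccc1)c1ccccc1`: 440 nM
compound 2, `CC(C)c1cccc(C(C)C)c1NC(=O)NC(=O)N(Cc1ccccc1)C(C)C`: 750 nM
compound 3, `CCCCCCCC(C)OC(=O)NC(=O)Nc1c(C(C)C)cccc1C(C)C`: 390 nM

All three compounds share the same core and were tested in an assay on microsomes from intestine for inhibition of acyl-CoA:cholesterol acyltransferase (Oryctolagus cuniculus); on this read-out lower numbers stand for stronger inhibition and higher numbers for weaker inhibition. Compound 3 gives 390 nM, the lowest of the three numbers. Compound 1 gives 440 nM and compound 2 gives 750 nM; both values lie within the scatter of compound 3, so the three cannot be told apart on this read-out.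

The next compound, compound 4 with structure `CCCCCCCCCCCCCCC(C)OC(=O)NC(=O)Nc1c(C(C)C)cccc1C(C)C`, differs from compound 3 in one place: heptyl in place of hydrogen on a saturated chain carbon, eight bonds along the chain from an oxygen next to a carbonyl group. The chain that carries the carbonyl-bound oxygen is thereby lengthened. Among the measured compounds shown here, nothing among the measured compounds shows what such a lengthening does in this assay, since no pair of them differs in that way alone.

The expectation for compound 4 is therefore cautious: in this assay a step of a 1.3-fold lower number from compound 3 to compound 4 (0.11 log units; within the scatter) is expected from compound 3, that is, roughly no change beyond the scatter, with a slight lean toward a lower number. The estimated value for compound 4 is 300 nM, within a range from 100 nM to 900 nM.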

Compound 4, half-maximal inhibitory concentration: 6800 nM
Compound 4: middle estimate off by 23-fold (1.36 log units), on the low side, outside the stated range (above it).
By their numbers in this assay, from the lowest: compounds 3, 1 and 2 (each within the scatter of the next); then compound 4.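

In this assay, heptyl in place of hydrogen on a saturated chain carbon, eight bonds along the chain from an oxygen next to a carbonyl group, gives a 17-fold higher number from compound 3 to compound 4 (1.24 log units; beyond the scatter) and so weakens inhibition clearly. This is the first pair shown that differs in one place only, and it reveals that this chain cannot be lengthened freely: the read-out responds strongly to a change at this position. Nothing available explains why the longer chain gives so much weaker inhibition.

As far as these compounds go, what remains open is how the number changes with chain lengths that fall between those of compound 3 and compound 4, such as propyl at this same place. From the compounds shown here alone, it is also open whether an amine or a carboxylic acid in place of heptyl would give a similar step.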